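Changing the group on the carbonyl carbon of a substance-P ligand

The source may report more compounds than this note shows. Statements on the series, on what has been measured and on what is new or still open speak of the compounds shown alone.

Of the compounds shown here, three built on one shared core have been tested in an assay on CHO cells for displacement of a labelled ligand from Substance-P receptor (Homo sapiens); a lower number here means a stronger inhibitor, a higher number a weaker inhibitor. Compound 1 `C[C@@H](O[C@@H]1CN(C=O)C[C@H]1c1ccc(F)cc1)c1cc(C(F)(F)F)cc(C(F)(F)F)c1`, which carries only hydrogen on its carbonyl carbon, gives 0.24 nM. Compound 2 `CCC(=O)N1C[C@@H](O[C@H](C)c2cc(C(F)(F)F)cc(C(F)(F)F)c2)[C@H](c2ccc(F)cc2)C1` gives 0.09 nM, and compound 3 `Cc1cnc(C(=O)N2C[C@@H](O[C@H](C)c3cc(C(F)(F)F)cc(C(F)(F)F)c3)[C@H](c3ccc(F)cc3)C2)cn1` gives 0.12 nM. Compound 3 therefore holds the second highest of the three numbers; the gap to its closest neighbour is a 1.3-fold higher number from compound 2 to compound 3 (0.12 log units; within the scatter), and the gap to the farthest is a 2.0-fold lower number from compound 1 to compound 3 (0.30 log units; within the scatter), so all three values lie close together.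

Compound 4 `C[C@@H](O[C@@H]1CN(C(=O)[C@@H]2COC(=O)N2)C[C@H]1c1ccc(F)cc1)c1cc(C(F)(F)F)cc(C(F)(F)F)c1` differs from compound 3 in one place only: 2-oxo-1,3-oxazolidin-4-yl in place of 5-methylpyrazin-2-yl on a carbonyl carbon. The steps already seen at this same carbonyl carbon are a 2.7-fold lower number from compound 1 to compound 2 (0.43 log units; beyond the scatter), a 2.0-fold lower number from compound 1 to compound 3 (0.30 log units; within the scatter) and a 1.3-fold higher number from compound 2 to compound 3 (0.12 log units; within the scatter). Only the first of these reaches beyond the scatter, and even it is modest, so changes at this position have so far moved this assay little. A step of a 1.3-fold higher number from compound 3 to compound 4 (0.10 log units; within the scatter) is therefore expected, essentially none beyond the scatter. Compound 4 is estimated at 0.15 nM, with a likely range from 0.05 nM to 0.5 nM.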

Compound 4, half-maximal inhibitory concentration: 0.34 nM
Estimate against measurement, compound 4: 2.3-fold (0.36 log units) below; the range from low to high includes it.
By their numbers in this assay, from the lowest: compounds 2, 3, 1 and 4 (each within the scatter of the next, the first and the last beyond it).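

This carbonyl carbon is not indifferent to what it carries: in this assay, 2-oxo-1,3-oxazolidin-4-yl gives a 2.8-fold higher number from compound 3 to compound 4 (0.45 log units; beyond the scatter) and a 3.8-fold higher number from compound 2 to compound 4 (0.58 log units; beyond the scatter), both modest but beyond the scatter. The same group set against plain hydrogen gives a 1.4-fold higher number from compound 1 to compound 4 (0.15 log units; within the scatter), so the effect of this ring depends on which group it is compared with, and the new hydrogen-bond donor and non-aromatic ring come with no penalty relative to hydrogen. No measurement here accounts for these steps.

From the compounds shown here alone, compound 4 changes several features at once, so the ring, its hydrogen-bond donor and its defined stereocentre cannot be separated, and the opposite arrangement at that stereocentre remains untested in these data. Going by these compounds, how an amine, a carboxylic acid or a chain longer than ethyl would behave on this carbonyl carbon also stays open.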